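The compounds below may be only part of what the source reports. "The series", "measured", "known", "first", "only" and "open" are said of these compounds alone.

Working notes on one series built around a shared core. Compound 1 `CN(C(=O)NC(=O)c1ccc([N+](=O)[O-])cc1)c1nc(C(F)(F)F)c(C(=O)N/N=C/c2ccc([N+](=O)[O-])cc2)s1`, compound 2 `CN(C(=O)NC(=O)c1ccc(F)c(F)c1)c1nc(C(F)(F)F)c(C(=O)N/N=C/c2cccc(C(F)(F)F)c2)s1` and compound 3 `CN(C(=O)NC(=O)c1ccc(F)c(F)c1)c1nc(C(F)(F)F)c(C(=O)N/N=C/c2ccc([N+](=O)[O-])cc2)s1` are measured; compound 4 `CN(C(=O)NC(=O)c1ccc([N+](=O)[O-])cc1)c1nc(C(F)(F)F)c(C(=O)N/N=C/c2cccc(C(F)(F)F)c2)s1` is not yet measured. In a functional assay on MCF7 cells (Homo sapiens) for inhibition, read by MTT assay, with a stated time of 72 h (on this read-out higher numbers stand for weaker inhibition and lower numbers for stronger inhibition), compound 1 gives 9.24 ug/mL. In this assay compound 2 gives 4.15 ug/mL. In this assay compound 3 gives 4.81 ug/mL.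

Two changes connect the measured compounds. The change 4-nitrophenyl in place of 3,4-difluorophenyl on a carbonyl carbon produced the step of a 1.9-fold higher number from compound 3 to compound 1 (0.28 log units; within the scatter). The change 3-(trifluoromethyl)phenyl in place of 4-nitrophenyl on a carbon with a double bond to nitrogen is seen in the step of a 1.2-fold higher number from compound 2 to compound 3 (0.06 log units; within the scatter), read in the opposite direction.

Compound 4 arises from compound 2 by 4-nitrophenyl in place of 3,4-difluorophenyl on a carbonyl carbon. The place is written the same way as for the change from compound 3 to compound 1, so this is the same change carried out on a core that differs by 3-(trifluoromethyl)phenyl in place of 4-nitrophenyl on a carbon with a double bond to nitrogen. The step from compound 2 to compound 4 in this assay is estimated at a 1.8-fold higher number from compound 2 to compound 4 (0.26 log units; within the scatter), resting on the earlier step of a 1.9-fold higher number from compound 3 to compound 1 (0.28 log units; within the scatter), with the two cores differing only in the way just told. Compound 4 is therefore expected to give about 7.5 ug/mL, with a range estimated from 4 ug/mL to 14 ug/mL.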

Compound 4, half-maximal inhibitory concentration: 4.39 ug/mL
For compound 4 the middle estimate is 1.7-fold (0.23 log units) above the measured one, within the range that was stated.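

In this assay, 4-nitrophenyl in place of 3,4-difluorophenyl on a carbonyl carbon gives a 1.1-fold higher number from compound 2 to compound 4 (0.02 log units; within the scatter), and the readings of this change on the two cores do not differ beyond the scatter: the same change on two cores in this assay, a 1.9-fold higher number (0.28 log units; within the scatter) from compound 3 to compound 1 and a 1.1-fold higher number (0.02 log units; within the scatter) from compound 2 to compound 4, 1.8-fold (0.26 log units) apart, within the scatter of two such steps. The other change, 3-(trifluoromethyl)phenyl in place of 4-nitrophenyl on a carbon with a double bond to nitrogen, gives a 2.1-fold lower number from compound 1 to compound 4 (0.32 log units; beyond the scatter), and its readings on the two cores also agree within the scatter: the same change on two cores in this assay, a 1.2-fold higher number (0.06 log units; within the scatter) from compound 2 to compound 3 and a 2.1-fold higher number (0.32 log units; beyond the scatter) from compound 4 to compound 1, 1.8-fold (0.26 log units) apart, within the scatter of two such steps. Both changes are therefore compatible with carrying over between these two cores, but this does not establish that they transfer to other cores, as each comparison rests on one pair of steps and these steps are too small to reveal a modest dependence on the core.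

The compounds shown carry only substituted phenyl groups at these two places. On these data alone, whether either change carries over in the same way when an amine, a carboxylic acid or a longer alkyl chain stands at one of these places remains open.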